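Removing the chloro group from a weak quinolinone-benzimidazole

The compounds below may be only part of what the source reports. "The series", "measured", "known", "first", "only" and "open" are said of these compounds alone.

Measured compounds:
compound 1, `O=c1[nH]c2ccccc2cc1-c1nc2cc(F)ccc2[nH]1`, 27500 nM in a functional assay on BEL-7404 cells for cytotoxicity against BEL-7404 tumor cell line (Homo sapiens), read by MTT assay, with a stated time of 48 h; a lower number here means a stronger inhibitor, a higher number a weaker inhibitor
compound 2, `COc1ccc2[nH]c(=O)c(-c3nc4cc(C)c(C)cc4[nH]3)cc2c1`, > 100000 nM in this assay
compound 3, `COc1ccc2[nH]c(=O)c(-c3nc4cc(Cl)ccc4[nH]3)cc2c1`, > 100000 nM in this assay

Among the measured compounds shown here, compound 1 is the only member of this small set with a numerical result, giving 27500 nM in this assay. For compound 2 the result is only a limit, > 100000 nM. For compound 3 the result is likewise only a limit, > 100000 nM, so its true potency is not pinned down. For the measured compounds named here, compound 3 thus stands at the limit of > 100000 nM in this assay, at which 2 of the 3 values shown sit, and no step between measured compounds differing in a single place is available to calibrate how a small change shifts the numbers here.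

Compound 4, `COc1ccc2[nH]c(=O)c(-c3nc4ccccc4[nH]3)cc2c1`, has not yet been tested. It differs from compound 3 by hydrogen in place of chloro on an aromatic carbon. Going by the values given here, since compound 3 sits at a limit, a step can only be expressed relative to that limit, and with no comparable measured step the expected change is none beyond the usual scatter. Compound 4 is therefore expected near 100000 nM, within a range from 30000 nM to 300000 nM. This corresponds to an expected step of a number no higher from compound 3 to compound 4 (the limit leaves the size open), and it is quite possible that the result will again be reported only as a limit.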

Compound 4, half-maximal inhibitory concentration: > 100000 nM
Compound 4: only a limit was reported (the forecaster's own chance of this, stated with the estimate: 60%); the middle value sits exactly at the limit.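

Among the compounds shown here, compound 3 and compound 4 are each reported only as a limit in this assay, so no step between them can be read: the limit of > 100000 nM in this assay, at which 3 of the 4 values shown sit. The compounds shown leave open whether hydrogen in place of chloro on an aromatic carbon changes the true potency at all, and if so, in which direction.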